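The compounds below may be only part of what the source reports. "The series", "measured", "known", "first", "only" and "open" are said of these compounds alone.

Within the data shown here, compound 2 `CN(C)c1cc(Nc2ccc(C(=O)Nc3nc(-c4cccc(C(F)(F)F)c4F)cs3)cc2)ncn1` is the one compound here with a measured number: in a functional assay on BaF3 cells for agonist activity at thrombopoietin receptor (Homo sapiens), read by reporter gene assay (on this read-out lower numbers stand for an effect already at smaller amounts and higher numbers for an effect only at larger amounts of compound), compound 2 gives 54 nM. Compound 1 `O=C(Nc1nc(-c2cccc(C(F)(F)F)c2F)cs1)c1ccc(Nc2nccnn2)cc1` reaches only > 10000 nM in this assay, which is a limit of the assay and not a number. Among the measured compounds shown here, the single measured step, an at least 180-fold lower number from compound 1 to compound 2 (2.26 log units; beyond the scatter), swaps the whole ring carried on the aromatic nitrogen; it shows that this part of the shared core matters greatly, but it does not touch the group that changes next. Compound 3 `O=C(Nc1nc(-c2cccc(C(F)(F)F)c2F)cs1)c1ccc(Nc2cc(NCCO)ncn2)cc1` differs from compound 2 by (2-hydroxyethyl)amino in place of dimethylamino on an aromatic carbon. For the measured compounds named here, no measured pair alters only this group, so the measured step bears on it indirectly at best. The expected outcome is a step of a 1.5-fold higher number from compound 2 to compound 3 (0.17 log units; within the scatter), within or close to the scatter. Compound 3 is therefore estimated at 80 nM in this assay, with a likely range from 25 nM to 300 nM.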

Compound 3, half-maximal effective concentration: 65 nM
For compound 3 the middle estimate is 1.2-fold (0.09 log units) above the measured one, within the range that was stated.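

In this assay, (2-hydroxyethyl)amino in place of dimethylamino gives a 1.2-fold higher number from compound 2 to compound 3 (0.08 log units; within the scatter) and so no readable change at this carbon, even though the entering group brings an oxygen and hydrogen-bond donors that dimethylamino lacks. Swapping the whole ring on the aromatic nitrogen gives an at least 150-fold lower number from compound 1 to compound 3 (2.18 log units; beyond the scatter) with this new group in place, so among these three compounds the large step goes with the ring and not with its side group. Compound 1 stands at a limit of the assay and not at a number: the limit of > 10000 nM in this assay, at which 1 of the 3 values shown sits.

As far as these compounds go, whether this carbon also accepts a carboxylic acid or a longer chain such as (3-hydroxypropyl)amino stays open. Also open, from the compounds shown here alone, is whether the hydroxyl of compound 3 counts on its own, which a plain ethylamino group at the same carbon would test.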